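A few compounds are considered here, and "the series" means these few. Any claim that something is new, unique, unknown or untested is made for them only; others in the source may bear on it.

Compound 1 `Cc1c(C)c2c(c(C)c1CCCCCCNC(=O)OCc1ccccc1)CCC(C)(COc1ccc(/C=C3\SC(=O)NC3=O)cc1)O2` and compound 2 `Cc1c(C)c2c(c(C)c1CCCCCCN)CCC(C)(COc1ccc(/C=C3\SC(=O)N(C)C3=O)cc1)O2` share the same core and differ in more than one place, so no single step can be read between them. In an ADME assay on cells (Hepatocyte, Homo sapiens) for cytotoxicity, read by MTT assay, with a stated time of 90 min, tested at 100 uM (on this read-out higher numbers stand for a weaker effect at the one concentration tested and lower numbers for a stronger effect), compound 1 gives 85.1%. In this assay compound 2 gives 82.6%, a number that lies within the scatter of the figure for compound 1, so the two cannot be told apart on this read-out; both stand at a weak effect. Compound 3 `Cc1c(C)c2c(c(C)c1CCCCCCN)CCC(C)(COc1ccc(/C=C3\SC(=O)NC3=O)cc1)O2` has not yet been measured. It differs from compound 2 by hydrogen in place of methyl on an amide-type nitrogen in a ring. For the measured compounds named here, no step between measured compounds is available to size this change, but both measured compounds sit at a weak effect, and compound 3 is therefore expected to remain there, with the expected step of a number 1.4 percentage points higher from compound 2 to compound 3 (within the scatter) staying within the scatter. Compound 3 is estimated at 84%, with a range from 72% to 94%.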

Compound 3, a percentage reported as activity, at one concentration (the size of the read-out at that concentration, not a potency): 83.2%
Compound 3: middle estimate off by 0.8 percentage points, on the high side; the measured number falls inside the stated range.
By their numbers in this assay, from the lowest: compounds 2, 3 and 1 (each within the scatter of the next).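

Hydrogen in place of methyl on the amide-type nitrogen in the ring now has a measured size in this assay: the change gives a number 0.6 percentage points higher from compound 2 to compound 3 (within the scatter) and so does not separate the two compounds on this read-out. Hydrogen in place of benzyloxycarbonyl on the amine nitrogen, a change that could not be read before, gives a number 1.9 percentage points lower from compound 1 to compound 3 (within the scatter) and likewise leaves the compounds indistinguishable. No measurement shown bears on why either change leaves the read-out where it stands.

The compounds shown leave open whether an ethyl group or a longer chain on the amide-type nitrogen in the ring, or an acetyl group on the amine nitrogen, would shift this read-out. From the compounds shown here alone, all three compounds stand at a weak effect at the one concentration tested, so what would give a stronger effect remains unknown.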